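This account rests on a few compounds, and the source may have more. Where it says the series, first, only, none or still open, it means among the compounds named here.

The measured compounds:
Compound 1 `Cc1nn(-c2cccc3cc(Cc4cccc(C(F)(F)F)c4)sc23)cc1C(=O)NCCO` gives 102% in a functional assay on CHO cells for agonist activity at G-protein coupled receptor 52 (Homo sapiens), read by AlphaScreen and cAMP accumulation, with a stated time of 30 min; a lower number here means a smaller maximal response, a higher number a larger maximal response.
Compound 2 `COCCNC(=O)c1cn(-c2cccc3cc(Cc4cccc(C(F)(F)F)c4)sc23)nc1C` gives 89% in this assay.
Compound 3 `Cc1c(C(=O)NCCO)c(CO)nn1-c1cccc2cc(Cc3cccc(C(F)(F)F)c3)sc12` gives 96% in this assay.

Compound 3 stands second highest of the three numbers, but its gaps to compound 1 and to compound 2 both lie within the scatter, so the three cannot be ordered. Compound 4 `Cc1nn(-c2cccc3cc(Cc4cccc(C(F)(F)F)c4)sc23)c(C)c1C(=O)NCCO` differs from compound 3 by hydrogen in place of hydroxy on a saturated chain carbon bound to an aromatic carbon; cut one bond further out, the change reads hydroxymethyl to methyl. Within the data shown here, no measured step touches this place. Among the measured compounds shown here, the only recorded step, a number 13 percentage points lower from compound 1 to compound 2 (beyond the scatter), concerns a different place, methyl in place of hydrogen on an oxygen on a saturated carbon, and is modest. For compound 4 the expected step of a number 1 percentage points lower from compound 3 to compound 4 (within the scatter) is therefore none beyond the scatter. Compound 4 is estimated at 95%, with a range from 80% to 106%.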

Compound 4, largest response reached (Emax), in percent of the reference or control that the assay uses: 110%
For compound 4 the middle estimate is 15 percentage points below the measured one; the measured number lies above the stated range.
By their numbers in this assay, from the lowest: compounds 2, 3, 1 and 4 (each within the scatter of the next, the first and the last beyond it).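

In this assay, among these compounds, the change from hydroxymethyl to methyl, hydrogen in place of hydroxy on a saturated chain carbon bound to an aromatic carbon, gives a number 14 percentage points higher from compound 3 to compound 4 (beyond the scatter) and is the first reading at this place. Methyl in place of hydrogen on an aromatic carbon gives a number 8 percentage points higher from compound 1 to compound 4 (within the scatter) so this added methyl shifts the response by no more than the scatter. No measurement available here accounts for the hydroxymethyl step. From the compounds shown here alone, what an amine, a carboxylic acid or a longer chain on that carbon would give remains open.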